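Replacing a phenolic hydroxy with methyl: expected lipophilicity

A few compounds are considered here, and "the series" means these few. Any claim that something is new, unique, unknown or untested is made for them only; others in the source may bear on it.

Measured compounds:
Compound 1, `Cc1c(NCc2nnc(Cc3ccccc3)o2)c(=O)n(-c2ccccc2)n1C`, gives 1.64 in a physicochemical assay for lipophilicity, measured as octanol-water partition; a lower number here means a more polar compound, a higher number a more lipophilic compound.
Compound 2, `Cc1c(NCc2nnc(-c3ccccc3O)o2)c(=O)n(-c2ccccc2)n1C`, gives 1.71.
Compound 3, `Cc1c(NCc2nnc(-c3ccccc3Cl)o2)c(=O)n(-c2ccccc2)n1C`, gives 2.72.

Compound 2 stands second highest of the three numbers. Its nearest neighbour is compound 1, and the step of a number 0.07 log units higher from compound 1 to compound 2 (within the scatter) lies within the scatter, so the two cannot be told apart. Its furthest neighbour is compound 3, reached by the step of a number 1.01 log units higher from compound 2 to compound 3 (beyond the scatter), which is large and beyond the scatter.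

Compound 4, `Cc1ccccc1-c1nnc(CNc2c(C)n(C)n(-c3ccccc3)c2=O)o1`, has not yet been measured. It differs from compound 2 by methyl in place of hydroxy on an aromatic carbon; the group that leaves carries one hydrogen-bond donor and one acceptor, the group that enters carries none.

The step that bears most directly on this change is a number 1.01 log units higher from compound 2 to compound 3 (beyond the scatter), where another group without donor or acceptor replaced the same hydroxy and the number rose by a large margin. The step of a number 1.08 log units higher from compound 1 to compound 3 (beyond the scatter) points the same way. A rise of a similar order is therefore expected for compound 4, with the step of a number 0.89 log units higher from compound 2 to compound 4 (beyond the scatter) estimated as clearly beyond the scatter. Compound 4 is expected to give about 2.6, with a range from 2.2 to 3.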

Compound 4, partition coefficient: 2.38
Estimate against measurement, compound 4: 0.22 log units above; measured number inside the range.
By their numbers in this assay, from the lowest: compounds 1 and 2 (each within the scatter of the next); then compound 4; then compound 3.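

Methyl is a second group without a hydrogen-bond donor or acceptor to replace hydroxy at this position, and in this assay it also raises the number, with a number 0.67 log units higher from compound 2 to compound 4 (beyond the scatter) in this change, so the rise seen with chloro is not unique to chloro. The two replacements can still be told apart, since a number 0.34 log units lower from compound 3 to compound 4 (beyond the scatter) separates methyl from chloro here. The 2-methylphenyl group also differs from benzyl, with a number 0.74 log units higher from compound 1 to compound 4 (beyond the scatter) in that exchange, whereas 2-hydroxyphenyl could not be told apart from benzyl.

From the compounds shown here alone, how an amine, a methoxy group or a longer chain such as ethyl would read at this position stays open. Nothing shown gives a measured reason for the different sizes of these steps.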